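From tetrazole to carboxymethyl on a shared core

A few compounds are considered here, and "the series" means these few. Any claim that something is new, unique, unknown or untested is made for them only; others in the source may bear on it.

Compound 1, `CC(C)(C)C(=O)CN1C(=O)N(CC(=O)Nc2cccc(-c3nc(=O)o[nH]3)c2)N=C(C2CCCCC2)c2ccccc21`: 9.55 nM
Compound 2, `CC(C)(C)C(=O)CN1C(=O)N(CC(=O)Nc2cccc(-c3nn[nH]n3)c2)N=C(C2CCCCC2)c2ccccc21`: 7.76 nM

In a functional assay on stomach for antagonist activity at Gastrin/cholecystokinin type B receptor (Rattus norvegicus) (on this read-out lower numbers stand for tighter binding and higher numbers for weaker binding), compound 2 gives the lower of the two numbers, yet the step of a 1.2-fold lower number from compound 1 to compound 2 (0.09 log units; within the scatter) is within the scatter, so the two compounds cannot be told apart. Compound 3, `CC(C)(C)C(=O)CN1C(=O)N(CC(=O)Nc2cccc(CC(=O)O)c2)N=C(C2CCCCC2)c2ccccc21`, carries carboxymethyl in place of 2H-tetrazol-5-yl on an aromatic carbon. Among the compounds with values here, the single measured step swapped one five-membered aromatic ring for another and barely moved the number; no step removes the ring altogether, so compound 3 has no close precedent. A modest weakening is expected, a 2.6-fold higher number from compound 2 to compound 3 (0.41 log units; beyond the scatter), giving compound 3 an estimated 20 nM, between 5 nM and 80 nM.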

Compound 3, dissociation constant: 9.77 nM
Estimate against measurement, compound 3: 2.0-fold (0.31 log units) above, and the stated range covers the measured number.
By their numbers in this assay, from the lowest: compounds 2, 1 and 3 (each within the scatter of the next).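

Removing the ring altogether leaves the read-out in this assay indistinguishable: the comparisons give a 1.3-fold higher number from compound 2 to compound 3 (0.10 log units; within the scatter) and a 1.0-fold higher number from compound 1 to compound 3 (0.01 log units; within the scatter). Among these three compounds, then, a five-membered aromatic ring is not required at this position for the number to stay within the scatter, since the open-chain carboxymethyl group matches both ring-bearing compounds. Nothing shown here explains why the three groups read alike. As far as these compounds go, whether an amine or a methyl ester at this position would also match remains open.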